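The compounds below may be only part of what the source reports. "The series", "measured", "known", "first", "only" and "open" are said of these compounds alone.

Compound 1 `Cc1c(C#N)cc(-c2ccc(S(C)(=O)=O)cc2)n1-c1cccc(F)c1` and compound 2 `Cc1c(C#N)cc(-c2ccc(S(C)(=O)=O)cc2)n1-c1ccc(F)c(F)c1` share one core and differ only in the aromatic ring carried on the ring nitrogen. In a functional assay on the whole organism (strain Swiss albino) for inhibition, with Mus musculus as the target, in the writhing test, with a stated time of 30 min, at a dose of 20 mg/kg by the oral route (a higher number here means a stronger effect of the compound at the dose given, a lower number a weaker effect), compound 1 gives 33%, and compound 2 gives 38%. Compound 2 thus stands at the higher of the two numbers, yet the step of a number 5 percentage points higher from compound 1 to compound 2 (within the scatter) lies within the scatter, so the two are not truly told apart. Compound 3 `Cc1c(C#N)cc(-c2ccc(S(C)(=O)=O)cc2)n1-c1ccccc1` has not yet been measured. Its change from compound 2 is phenyl in place of 3,4-difluorophenyl on an aromatic nitrogen, so both fluorine atoms leave. Among the measured compounds shown here, the only measured step that bears on this is the one between compound 1 and compound 2, which was small. Taking the fluorines away is therefore expected to move the number little, with an estimated step of a number 5 percentage points lower from compound 2 to compound 3 (within the scatter) that need not exceed the scatter. In this assay compound 3 is expected to give about 33%, within a range from 18% to 48%.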

Compound 3, a percentage reported as inhibition, in the whole organism at one dose (the size of the read-out at that dose, not a potency): 42%
Compound 3: the middle estimate sits 9 percentage points below what was measured; the range from low to high includes it.
By their numbers in this assay, from the lowest: compounds 1, 2 and 3 (each within the scatter of the next).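

In this assay the unsubstituted ring now stands with the two fluorinated ones: the change to phenyl gives a number 4 percentage points higher from compound 2 to compound 3 (within the scatter) and the swap of the single fluoro for hydrogen gives a number 9 percentage points higher from compound 1 to compound 3 (within the scatter), so neither step separates the compounds. On this aromatic nitrogen, then, the phenyl ring needs no fluorine to give a read-out of this size, which the two fluorinated compounds could not show by themselves. Nothing available explains why these steps are so small.

As far as these compounds go, it remains open whether a different group on the phenyl ring, such as a methoxy group, an amine or a carboxylic acid, would move the number beyond the scatter. A read-out at one dose also leaves open whether these compounds would stay together at other doses.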